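A Trifluoromethyl Benzyl Analogue in a Cytotoxicity Series

The compounds below may be only part of what the source reports. "The series", "measured", "known", "first", "only" and "open" are said of these compounds alone.

compound 1, `Cc1ccc(CN2C(=O)S/C(=C\c3cccc(N)c3)C2=O)cc1` — 98000 nM
compound 2, `Nc1cccc(/C=C2\SC(=O)N(Cc3ccccc3)C2=O)c1` — > 250000 nM

The two measured compounds share one core and differ at a single aromatic carbon. In a functional assay on HeLa cells (Homo sapiens) for cytotoxicity, read by cell counting, with a stated time of 4 days (a lower number here means a stronger inhibitor, a higher number a weaker inhibitor), compound 1 gives 98000 nM. For compound 2 this assay reports only a limit, > 250000 nM, so compound 2 stands at the weak end of what has been measured, with no number of its own. For the measured compounds named here, the one measured comparison, an at least 2.5-fold higher number from compound 1 to compound 2 (0.40 log units; beyond the scatter), ends at the limit of > 250000 nM in this assay, at which 1 of the 2 values shown sits.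

Compound 3, `Nc1cccc(/C=C2\SC(=O)N(Cc3ccc(C(F)(F)F)cc3)C2=O)c1`, differs from compound 2 by trifluoromethyl in place of hydrogen on an aromatic carbon. Going by the values given here, the only measured step that touches the same aromatic carbon is an at least 2.5-fold higher number from compound 1 to compound 2 (0.40 log units; beyond the scatter), which moved toward a higher number when a group left that carbon; compound 3 runs the other way, a group entering it. On that basis compound 3 is expected to give a lower number than the limit seen for compound 2, though the size is uncertain since the measured step is itself only a bound. For compound 3 the expected step is an at least 2.5-fold lower number from compound 2 to compound 3 (0.39 log units; beyond the scatter). Compound 3 is therefore estimated at 100000 nM, within 30000 nM to 300000 nM.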

Compound 3, half-maximal inhibitory concentration: > 250000 nM
Compound 3 gave a limit, no number; the forecaster's own chance of this, stated with the estimate: 40%; middle value at least 2.5-fold (0.39 log units) from the limit.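

At this aromatic carbon, para to a large group, trifluoromethyl does not behave as methyl does in this assay: the change gives an at least 2.5-fold higher number from compound 1 to compound 3 (0.40 log units; beyond the scatter), a shift that matches the one seen on removing methyl, an at least 2.5-fold higher number from compound 1 to compound 2 (0.40 log units; beyond the scatter). Having a group at this carbon is therefore not enough on its own to give a measured number, and among the three compounds only the methyl of compound 1 does so. The step from compound 2 to compound 3 cannot be read, and the two compounds can only be placed together: the limit of > 250000 nM in this assay, at which 2 of the 3 values shown sit.

Going by these compounds, what remains open is whether the activity of compound 1 is particular to methyl, or whether a group such as ethyl, methoxy or chlorine at this same carbon would also give a measured number. Also open, on these data alone, is how far compound 2 and compound 3 actually lie from each other, and whether trifluoromethyl at this carbon would read differently on a core carrying something other than the amine.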